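A few compounds are considered here, and "the series" means these few. Any claim that something is new, unique, unknown or untested is made for them only; others in the source may bear on it.

Compound 1 `CCCC[C@H](NC(=O)[C@H](CCCCN)NC(=O)[C@H](CCCNC(=N)N)NC(=O)c1ccc(/C=C2\SC(=S)N(c3ccc(Cl)cc3)C2=O)cc1)C(N)=O`: 1.02 10^-6 cm/s
Compound 2 `CCCC[C@H](NC(=O)[C@H](CCCCN)NC(=O)[C@H](CCCNC(=N)N)NC(=O)c1cccc(/C=C2\SC(=O)N(C3CCCC3)C2=O)c1)C(N)=O`: 1.9 10^-6 cm/s

In an ADME assay for permeability, using PAMPA (on this read-out lower numbers stand for lower permeability and higher numbers for higher permeability), compound 1 gives 1.02 10^-6 cm/s, the lower of the two numbers seen so far. Compound 2 gives 1.9 10^-6 cm/s in this assay, and the two values lie within the scatter of each other, so nothing can be said about an order between them. Compound 3 `CCCC[C@H](NC(=O)[C@H](CCCCN)NC(=O)[C@H](CCCNC(=N)N)NC(=O)c1ccc(/C=C2\SC(=S)N(C3CCCCC3)C2=O)cc1)C(N)=O` differs from compound 1 in one place: cyclohexyl in place of 4-chlorophenyl on an amide-type nitrogen in a ring. Among the compounds with values here, no measured pair shows the effect of such a change, and the two numbers available are close and both low. On that basis the step from compound 1 is expected to be small, with no direction that can be told apart from the scatter. The expected step of a 1.3-fold higher number from compound 1 to compound 3 (0.11 log units; within the scatter) is thus estimated to remain within the usual spread of repeated measurements. Compound 3 is expected to give about 1.3 10^-6 cm/s in this assay, with a range from 0.6 10^-6 cm/s to 2.8 10^-6 cm/s.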

Compound 3, apparent permeability: 1.82 10^-6 cm/s
Estimate against measurement, compound 3: 1.4-fold (0.15 log units) below; low and high end bracket the measured number.
By their numbers in this assay, from the lowest: compounds 1, 3 and 2 (each within the scatter of the next).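

This is the first comparison among these compounds that changes one place alone, and it concerns the amide-type nitrogen in the five-membered non-aromatic ring with 1 nitrogen and 1 sulfur. In this assay, cyclohexyl in place of 4-chlorophenyl at this position gives a 1.8-fold higher number from compound 1 to compound 3 (0.25 log units; within the scatter), so the exchange of an aromatic carbon ring carrying chlorine for a non-aromatic carbon ring, one heavy atom smaller, is not resolved from the usual spread of repeated measurements. Nothing measured accounts for this result or explains why the two groups cannot be told apart in this read-out.

The compounds shown leave open whether a different kind of group on this nitrogen, such as a carboxylic acid, an amine or a longer chain, would give a step beyond the scatter, since both groups compared here are six-membered carbon rings without hydrogen-bond donors or acceptors. They also leave open whether the same exchange would give a similar step on another core, as compound 2 differs from compound 1 and compound 3 in more than one place and offers no direct comparison.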